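The source may report more compounds than this note shows. Statements on the series, on what has been measured and on what is new or still open speak of the compounds shown alone.

Compound 1, `C=C1C[C@]23C[C@@]1(O)CC[C@H]2c1ccc(OS(=O)(=O)c2ccc(C)cc2)c(C)c1[C@@H]3Cn1cc(-c2ccc(Cl)cc2)nn1`, carries a 4-chlorophenyl on its triazole. In a functional assay on MCF7 cells (Homo sapiens) for cytotoxicity, read by MTT assay, with a stated time of 4 days (on this read-out higher numbers stand for weaker inhibition and lower numbers for stronger inhibition), compound 1 reaches only the limit of the assay, > 20000 nM. Compound 1 thus sits at the limit of > 20000 nM in this assay, at which 2 of the 3 values shown sit. Compound 3, `Cc1ccc(S(=O)(=O)Oc2ccc3c(c2C)[C@H](Cn2cc(-c4ccccn4)nn2)[C@@]24CC(=O)[C@@](C)(CC[C@@H]32)C4)cc1`, is the other one at that limit: in this assay compound 3 gives > 20000 nM. Compound 2, `C=C1C(=O)[C@]23C[C@@]1(O)CC[C@H]2c1ccc(OS(=O)(=O)c2ccc(C)cc2)c(C)c1[C@@H]3Cn1cc(-c2ccc(Cl)cc2)nn1`, is the single one of the three with a number rather than a limit, as in this assay compound 2 gives 1440 nM.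

Compound 4, `C=C1C[C@]23C[C@@]1(O)CC[C@H]2c1ccc(OS(=O)(=O)c2ccc(C)cc2)c(C)c1[C@@H]3Cn1cc(-c2ccc(OC)cc2)nn1`, differs from compound 1 by methoxy in place of chloro on an aromatic carbon. With compound 1 already at the limit, nothing in the numbers shown points to a gain from this change, and compound 4 is expected to stay at the limit as well. The step expected from this change, a step that the limit leaves unreadable from compound 1 to compound 4, is none beyond the scatter. Compound 4 is therefore estimated at 30000 nM, with a range from 12000 nM to 100000 nM.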

Compound 4, half-maximal inhibitory concentration: > 20000 nM
Compound 4 was reported as a limit (the forecaster's own chance of this, stated with the estimate: 80%); the middle value does not contradict the limit.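

Compound 1 and compound 4 both stand at a limit of this assay rather than at a number, so no step can be read between them: the limit of > 20000 nM in this assay, at which 3 of the 4 values shown sit.

The compounds shown leave open whether 4-chlorophenyl and 4-methoxyphenyl differ at all in this assay.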